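Nitro to hydrogen on the shared core: solubility notes

The source may report more compounds than this note shows. Statements on the series, on what has been measured and on what is new or still open speak of the compounds shown alone.

Measured so far in a physicochemical assay for solubility; on this read-out higher numbers stand for higher solubility and lower numbers for lower solubility:
compound 1, `NC(=O)c1cccc(NC(=O)c2cc3ccccc3s2)c1`, a limit of the assay rather than a number: < 5 ug/mL
compound 2, `NC(=O)c1ccccc1NC(=O)c1cc2cc([N+](=O)[O-])ccc2s1`, 10 ug/mL
compound 3, `NC(=O)c1cccc(NC(=O)c2cc3cc([N+](=O)[O-])ccc3s2)c1`, 25 ug/mL

Compound 3 gives a higher number than compound 2 in this assay, beyond the scatter; the difference between the two cores is not broken down here. Within the data shown here, the one step that is measured is hydrogen in place of nitro on an aromatic carbon, and on this assay it gave an at least 5.0-fold lower number from compound 3 to compound 1 (0.69 log units; beyond the scatter), the value of compound 1 sitting at the limit of < 5 ug/mL in this assay, at which 1 of the 3 values shown sits.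

Compound 4, `NC(=O)c1ccccc1NC(=O)c1cc2ccccc2s1`, is not yet measured. It differs from compound 2 by hydrogen in place of nitro on an aromatic carbon, the same change that leads from compound 3 to compound 1. Compound 2 already starts lower than compound 3 in this assay, so a step of like size is expected to carry compound 4 to the limit of the assay, an expected change of a 4.0-fold lower number from compound 2 to compound 4 (0.60 log units; beyond the scatter); this rests on the measured at least 5.0-fold lower number from compound 3 to compound 1 (0.69 log units; beyond the scatter). For compound 4 the estimate is 2.5 ug/mL, expected between 1 ug/mL and 7 ug/mL, most likely reported only as a limit.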

Compound 4, solubility: < 5 ug/mL
Compound 4: no number, only a limit (the forecaster's own chance of this, stated with the estimate: 75%); the middle value lies beyond the limit too.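

In this assay compound 4 gives < 5 ug/mL as a limit of the assay and not a number. Hydrogen in place of nitro on an aromatic carbon gives an at least 2.0-fold lower number from compound 2 to compound 4 (0.30 log units; that floor lies within the scatter) on this core and so agrees in direction with the step on the core of compound 1, but taken alone this step does not establish a change beyond the scatter. The true size of the change on either core cannot be read and the two steps cannot be compared, because compound 1 and compound 4 both end at the same limit: the limit of < 5 ug/mL in this assay, at which 2 of the 4 values shown sit.

Only nitro and hydrogen are shown on this aromatic carbon, so what an amine or a carboxylic acid there would give in this assay remains open. Also open, on these data alone, is whether the change carries to any core beyond these two, and how compound 1 and compound 4 stand against each other, as neither has a number.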